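Fixing one stereocentre: a cytotoxicity estimate

The source may report more compounds than this note shows. Statements on the series, on what has been measured and on what is new or still open speak of the compounds shown alone.

Compound 1 `COc1cc(-c2ccc(C#N)cc2)ccc1[C@H](O)c1ccnc(Nc2ccc(C#N)cc2)n1` gives 9070 nM
Compound 2 `N#Cc1ccc(Nc2nccc(C(O)c3ccc(-c4ccc(C#N)cc4)cc3F)n2)cc1` gives 14300 nM

In an ADME assay on MT4 cells (Homo sapiens) for cytotoxicity, read by MTT assay, with a stated time of 5 days (on this read-out higher numbers stand for lower toxicity in this test and lower numbers for higher toxicity in this test), compound 2 gives 14300 nM and lies within the usual scatter of compound 1 at 9070 nM in this two-compound set. The next compound is compound 3 `N#Cc1ccc(Nc2nccc([C@@H](O)c3ccc(-c4ccc(C#N)cc4)cc3F)n2)cc1` and the change is small: the two compounds have the same atoms and bonds; at least one stereo element is drawn with a configuration in one of them and without one in the other: 1 of 1 stereo elements differ; a stereocentre at a saturated chain carbon is drawn without a configuration in compound 2 and S in compound 3 so the two compounds have the same atoms and bonds, with a stereocentre at a saturated chain carbon drawn without a configuration in compound 2 and S in compound 3. Among the measured compounds shown here, no measured pair here shows what such a change does in this assay so no shift beyond the scatter is expected, in either direction. The expected change is a 1.1-fold lower number from compound 2 to compound 3 (0.04 log units; within the scatter) and it stays within that scatter. Compound 3 is estimated at about 13000 nM (6500 nM to 26000 nM).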

Compound 3, half-maximal cytotoxic concentration: 7500 nM
Beside the measured number, compound 3's estimate is 1.7-fold (0.24 log units) above it; measured number inside the range.
By their numbers in this assay, from the lowest: compounds 3, 1 and 2 (each within the scatter of the next).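

In this assay, defining the stereocentre at a saturated chain carbon as S gives a 1.9-fold lower number from compound 2 to compound 3 (0.28 log units; within the scatter), so this first measured stereo change moves the number no further than repeat measurements would. The second step, a 1.2-fold lower number from compound 1 to compound 3 (0.08 log units; within the scatter), shows that fluoro in place of methoxy on an aromatic carbon also stays within that scatter when both compounds have a drawn configuration. What the first step can say about configuration remains limited because of one point: the fact that one of compounds 2 and 3 is drawn with a defined configuration and the other without, at the place where they differ

The compounds shown leave open how a compound drawn R at this stereocentre would read in this test. They also leave open whether an amine or a chloro group on that aromatic carbon would give a shift beyond the scatter.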